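This account rests on a few compounds, and the source may have more. Where it says the series, first, only, none or still open, it means among the compounds named here.

Compound 1 `CCN(Cc1cccs1)C(=O)COc1ccc(F)cc1` gives 422 nM.
Compound 2 `Cc1ccc(OCC(=O)N(Cc2cccs2)c2ccn(C)n2)cc1` gives 855 nM.
Compound 3 `CCN(Cc1cccs1)C(=O)c1cc2cc(C)ccc2[nH]1` gives 2010 nM.

All three were measured in an assay on HEK293 cells for agonist activity at transient receptor potential cation channel subfamily M member 8 (Homo sapiens), read by fluorescence and calcium flux, with a stated time of 15 min; on this read-out higher numbers stand for an effect only at larger amounts of compound and lower numbers for an effect already at smaller amounts. Among them, compound 2 holds the second highest of the three numbers. Its nearest neighbour is compound 1, whose number is lower by a gap that lies beyond the usual scatter; compound 3 is the furthest away, with a higher number, again beyond the scatter. No two of these compounds differ from one another in only one place, so no single step between measured compounds can be read off.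

Compound 4 `Cc1ccc(OCC(=O)N(Cc2cccs2)C(C)(C)C)cc1` has not yet been measured. It differs from compound 2 by tert-butyl in place of 1-methyl-1H-pyrazol-3-yl on an amide-type nitrogen. Since nothing in the measured set isolates this change, the expectation for compound 4 rests on the value of compound 2, 855 nM, together with the observation that compound 1, which carries a small saturated chain on the amide-type nitrogen, gives a lower number, 422 nM, though compound 1 also differs in its aromatic ring. The step from compound 2 to compound 4 is therefore estimated as a 1.4-fold lower number from compound 2 to compound 4 (0.15 log units; within the scatter), a modest move toward a lower number that may not exceed the scatter. Compound 4 is expected to give about 600 nM in this assay, within a range from 150 nM to 3000 nM.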

Compound 4, half-maximal effective concentration: 11000 nM
Beside the measured number, compound 4's estimate is 18-fold (1.26 log units) below it; the measured number lies above the stated range.
By their numbers in this assay, from the lowest: compound 1; then compound 2; then compound 3; then compound 4.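

In this assay, for the compounds shown here, compound 2 and compound 4 give the first comparison in which a single place changes, and the exchange on the amide-type nitrogen produces a 13-fold higher number from compound 2 to compound 4 (1.11 log units; beyond the scatter). The earlier compounds shown here all differ in more than one place, so they could not show that the group at this nitrogen alone can move the number this far. The exchange replaces one five-membered aromatic ring with 2 hetero atoms by tert-butyl, which has no ring and no hydrogen-bond acceptors, but no measurement shown here separates these differences or explains the step.

The compounds shown leave open whether another aromatic ring on this nitrogen, such as a pyridyl ring, would keep a number close to that of compound 2, and whether a saturated group smaller than tert-butyl, such as isopropyl, would avoid the rise. They also leave open whether the same exchange would have a similar effect with the other groups on the carbonyl carbon, such as those in compound 1 and compound 3.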